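This account rests on a few compounds, and the source may have more. Where it says the series, first, only, none or still open, it means among the compounds named here.

In a functional assay on A549 cells (Homo sapiens) for cytotoxicity, read by MTT assay, with a stated time of 72 h (on this read-out higher numbers stand for weaker inhibition and lower numbers for stronger inhibition), three compounds sharing one core have been measured. Compound 1 `O=C1c2c[n+]([O-])c3ccccc3c2C(=O)c2c1c1ccccc1n2Cc1cn([C@@H]2C[C@H](O)[C@@H](CO)O2)nn1` gives 120 nM, compound 2 `O=C1c2c[n+]([O-])c3ccccc3c2C(=O)c2c1c1ccccc1n2Cc1cn(CC(O)CO)nn1` gives 880 nM, and compound 3 `O=C1c2c[n+]([O-])c3ccccc3c2C(=O)c2c1c1ccccc1n2CCCCN1CCNCC1` gives 540 nM. Compound 3 therefore has the middle number of the three: it lies within the usual scatter of compound 2, while compound 1 has a clearly lower number.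

Compound 4 `CN1CCN(CCCCCCn2c3c(c4ccccc42)C(=O)c2c[n+]([O-])c4ccccc4c2C3=O)CC1` keeps the core and differs from compound 3 at the end of the side chain: 2-(4-methylpiperazin-1-yl)ethyl in place of piperazin-1-yl on a saturated chain carbon, four bonds along the chain from an aromatic nitrogen. Here, 2-(4-methylpiperazin-1-yl)ethyl stands in place of piperazin-1-yl on a saturated chain carbon, four bonds along the chain from an aromatic nitrogen.

Among the measured compounds shown here, no measured pair tests this exact change, so two less direct steps must serve as a guide. The step of a 1.6-fold lower number from compound 2 to compound 3 (0.21 log units; within the scatter) brought in 3-(piperazin-1-yl)propyl and stayed within the scatter, even though a whole side-chain group was replaced. The step of a 7.3-fold higher number from compound 1 to compound 2 (0.87 log units; beyond the scatter) went beyond the scatter, but it involves a group that is absent from compound 4, so it bears on this change only weakly. No step beyond the scatter is therefore expected in this assay, in either direction. The expected change is a 1.2-fold lower number from compound 3 to compound 4 (0.08 log units; within the scatter). For compound 4, the estimated value is 450 nM, with an expected range of 150 nM to 1400 nM.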

Compound 4, half-maximal inhibitory concentration: 330 nM
For compound 4 the middle estimate is 1.4-fold (0.13 log units) above the measured one; the measured number falls inside the stated range.
By their numbers in this assay, from the lowest: compound 1; then compounds 4, 3 and 2 (each within the scatter of the next, the first and the last beyond it).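

In this assay, the step from piperazin-1-yl to 2-(4-methylpiperazin-1-yl)ethyl (a 1.6-fold lower number from compound 3 to compound 4 (0.21 log units; within the scatter)) shows that this place, on a saturated chain carbon four bonds along the chain from an aromatic nitrogen, tolerates a larger end group, with 9 heavy atoms in place of 6 and 0 hydrogen-bond donors in place of 1, without the number leaving the scatter. Measured against compound 2, the 5-(4-methylpiperazin-1-yl)pentyl chain of compound 4 gives a modest step beyond the scatter (a 2.7-fold lower number from compound 2 to compound 4 (0.43 log units; beyond the scatter)), which the shorter piperazine chain of compound 3 did not give, although compounds 3 and 4 themselves cannot be told apart in this assay. Nothing available here explains these numbers.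

From the compounds shown here alone, two things change at once in compound 4, the chain length and the methyl on the piperazine ring, so their separate contributions remain unknown; a 4-methylpiperazin-1-yl group on the chain of compound 3 would begin to separate them. Going by these compounds, it also stays open whether the ring matters at all, which a chain ending in a morpholine ring or a simple dimethylamino group would test.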